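Taking One Hydroxy From Compound 2

A few compounds are considered here, and "the series" means these few. Any claim that something is new, unique, unknown or untested is made for them only; others in the source may bear on it.

Of the compounds shown here, two sharing one core have been measured in a functional assay on WRL68 cells (Homo sapiens) for cytotoxicity, read by MTT assay, with stated times of 6 h and 48 h; a higher number here means a weaker inhibitor, a lower number a stronger inhibitor. Compound 1 `Cn1c(/C=C/C(=O)c2ccccc2)cc(Br)c1Br`, which has no hydroxy group on its six-membered aromatic ring of carbon only, reads >= 100000 nM, and this is a limit of the assay, not a number. Within the data shown here, compound 2 `Cn1c(/C=C/C(=O)c2ccc(O)cc2O)cc(Br)c1Br` gives 180 nM, the only actual number so far, with nothing else to rank it against.

Compound 3 `Cn1c(/C=C/C(=O)c2ccc(O)cc2)cc(Br)c1Br` is still unmeasured. It differs from compound 2 by hydrogen in place of hydroxy on an aromatic carbon, ortho to a large group and meta to a hydroxy group. Among the measured compounds shown here, no single-change step between measured compounds is available to size this edit. The expectation rests on compound 2 at 180 nM and on compound 1, which lacks both hydroxy groups, so compound 3 is expected to fall somewhere between them. In this assay, a change beyond the scatter towards weaker inhibition is expected, and the estimated step is a 28-fold higher number from compound 2 to compound 3 (1.44 log units; beyond the scatter). Compound 3 is estimated at 5000 nM, with an expected range of 400 nM to 60000 nM.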

Compound 3, half-maximal inhibitory concentration: 1910 nM
Compound 3: the middle estimate sits 2.6-fold (0.42 log units) above what was measured; the measured number falls inside the stated range.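

In this assay, the hydroxy group ortho to a large group and meta to a hydroxy group now has a measured size of its own: hydrogen in its place gives an 11-fold higher number from compound 2 to compound 3 (1.03 log units; beyond the scatter), so this position still counts when the other hydroxy group stays. The other hydroxy group also counts, since setting it on the six-membered aromatic ring of carbon only, in the frame of compound 1, gives an at least 52-fold lower number from compound 1 to compound 3 (1.71 log units; beyond the scatter). Compound 1 reads at a limit and not at a number, so that second step gives only a minimum size: the limit of >= 100000 nM in this assay, at which 1 of the 3 values shown sits.

What stands at this position beyond hydroxy and hydrogen remains open: a methoxy group, a fluorine atom or an amine could each sit on the same aromatic carbon, and the compounds shown do not say how any of them would read in this assay. Among these compounds, also open is how a compound carrying only the hydroxy group at this position, without the one kept in compound 3, would compare, so the separate weight of each of the two hydroxy groups cannot yet be set side by side.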